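The source may report more compounds than this note shows. Statements on the series, on what has been measured and on what is new or still open speak of the compounds shown alone.

In a functional assay on MOLT-4 cells (Homo sapiens) (a higher number here means a weaker inhibitor, a lower number a stronger inhibitor), compound 1 (`COc1ccc(C(=O)Oc2ccc(/C=C3\CCCCC3=O)cc2)cc1`) gives 34000 nM and compound 2 (`CN(C)CC1CCC/C(=C\c2ccc(OC(=O)c3ccccc3)cc2)C1=O`) gives 24100 nM on the same read-out, so the two stand within the scatter of each other. Compound 3 (`COc1ccc(C(=O)Oc2ccc(/C=C3\CCCC(CN(C)C)C3=O)cc2)cc1`) departs from compound 2 through methoxy in place of hydrogen on an aromatic carbon. For the measured compounds named here, no measured pair shows this change alone, and no step beyond the scatter is expected in this assay in either direction. The estimated move is a 1.2-fold lower number from compound 2 to compound 3 (0.08 log units; within the scatter) and is expected to stay small. The expected value for compound 3 is 20000 nM (estimated range 8000 nM to 50000 nM).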

Compound 3, half-maximal inhibitory concentration: 2360 nM
Estimate against measurement, compound 3: 8.5-fold (0.93 log units) above, outside the stated range (below it).
By their numbers in this assay, from the lowest: compound 3; then compounds 2 and 1 (each within the scatter of the next).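

In this assay, phenyl to 4-methoxyphenyl, para to a large group, gives a 10-fold lower number from compound 2 to compound 3 (1.01 log units; beyond the scatter), so with the (dimethylamino)methyl in place, this methoxy carries a large step. Putting (dimethylamino)methyl in place of hydrogen on a saturated ring carbon, with the methoxy present, gives a 14-fold lower number from compound 1 to compound 3 (1.16 log units; beyond the scatter), so compound 3, which carries both groups, stands clear of both compounds that differ from it in one place. Nothing at hand bears on the cause of either step. The compounds shown leave open whether these steps depend on both groups being present, and whether a hydroxyl or ethoxy in place of the methoxy, or a piperidine in place of the dimethylamino, would give steps of like size.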